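Cyclopropyl in place of methyl on the carbonyl of compound 2

This account rests on a few compounds, and the source may have more. Where it says the series, first, only, none or still open, it means among the compounds named here.

Measured compounds:
compound 1, `CC1=C(C(=O)C2CC2)C(c2ccoc2)NC(=O)N1`, 10%
compound 2, `CC(=O)C1=C(C)NC(=O)NC1c1ccsc1`, 24%

In an assay on membranes from HEK293 cells for displacement of a labelled ligand from adenosine receptor A2b (Homo sapiens), read by scintillation counting, with a stated time of 30 min, tested at 1 uM (a higher number here means more inhibition at the concentration tested (going by the name of the read-out), a lower number less inhibition), compound 2 gives 24%, the higher of the two numbers shown. Its nearest neighbour on the numbers is compound 1, which in this assay gives 10%, a gap that lies beyond the usual scatter. Among the compounds with values here, compound 1 and compound 2 differ in more than one place, so no single step between them has been worked out; their two values are all that can be said of that pair.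

Compound 3, `CC1=C(C(=O)C2CC2)C(c2ccsc2)NC(=O)N1`, has not yet been measured in this assay. It differs from compound 2 in one place: cyclopropyl in place of methyl on a carbonyl carbon. Within the data shown here, no measured pair shows this change alone, so there is no step to lean on, only the two values above.

Compound 3 is therefore expected to stay close to compound 2, with a step of a number 7 percentage points lower from compound 2 to compound 3 (within the scatter) that should sit within the scatter, if anything slightly lower. The estimate for compound 3 in this assay is 17%, with a range from 5% to 32%.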

Compound 3, a percentage reported as inhibition, at one concentration (the size of the read-out at that concentration, not a potency): 1%
The estimate for compound 3 lay 16 percentage points above the measured number; the whole stated range lies above it.
By their numbers in this assay, from the lowest: compounds 3 and 1 (each within the scatter of the next); then compound 2.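

With the thiophen-3-yl held constant, this pair isolates cyclopropyl in place of methyl on the carbonyl carbon, and in this assay the change gives a number 23 percentage points lower from compound 2 to compound 3 (beyond the scatter) as a measured step. In this one pair, acetyl therefore reads better than cyclopropylcarbonyl at this position, by a margin that the earlier comparison of compound 1 and compound 2 could not assign to either group, since those compounds differ in more than one place. With cyclopropylcarbonyl held constant, thiophen-3-yl in place of furan-3-yl on the saturated ring carbon gives a number 9 percentage points lower from compound 1 to compound 3 (within the scatter) and so shows no readable difference between these two rings in this pair.

The compounds shown do not tell whether the acetyl advantage also holds with furan-3-yl on the core, or how an ethyl, an isopropyl or a phenyl on the carbonyl carbon would read in this assay at this single tested concentration. Nothing available here bears on why the step from acetyl to cyclopropylcarbonyl has the size it has.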